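Long-chain member: amino in place of methoxy

The source may hold more compounds than are shown below. What is called first, only, known or untested is meant among the compounds shown, and "the series" means these compounds.

Within the data shown here, in a functional assay on HCT-116 cells (Homo sapiens) for antiproliferative activity, read by MTT assay, with a stated time of 48 h (a higher number here means a weaker inhibitor, a lower number a stronger inhibitor), compound 3 (`CCCCCCCCCCCC(CCO)n1cnc2c(OC)ncnc21`) gives 8230 nM and compound 2 (`CCCCCCCCC(CCO)n1cnc2c(N)ncnc21`) gives 11600 nM as the only two numbers so far, and they lie within the scatter of each other. Compound 1 (`CCCCCCC(CCO)n1cnc2c(N)ncnc21`) gives > 50000 nM as a limit of the assay and not a number.

Compound 4 (`CCCCCCCCCCCC(CCO)n1cnc2c(N)ncnc21`) keeps the chain of compound 3 and carries amino in place of methoxy on an aromatic carbon, the group also found in compounds 1 and 2. Among the measured compounds shown here, no measured step covers this exchange directly. For the measured compounds named here, the one step that bears on it is an at least 4.3-fold lower number from compound 1 to compound 2 (0.63 log units; beyond the scatter) for ethyl in place of hydrogen on a saturated chain carbon. That step concerns the chain among amino compounds, and its size is only a bound set by the limit of compound 1.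

If the same trend holds, compound 4 with its longer chain should fall below compound 2. The chain and the group at the exchanged carbon cannot be separated on these data, so only a modest change is expected. The estimated change is a 2.1-fold lower number from compound 3 to compound 4 (0.31 log units; beyond the scatter) in this assay and lies toward a lower number. Compound 4 is expected at 4000 nM (estimated range 1300 nM to 13000 nM).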

Compound 4, half-maximal inhibitory concentration: 13400 nM
For compound 4 the middle estimate is 3.4-fold (0.53 log units) below the measured one; measured number outside the range, above it.
By their numbers in this assay, from the lowest: compounds 3, 2 and 4 (each within the scatter of the next). At a limit, above all of these: compound 1.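

Amino in place of methoxy on this aromatic carbon gives a 1.6-fold higher number from compound 3 to compound 4 (0.21 log units; within the scatter) in this assay, so at this chain length the exchange leaves no readable change, and the first direct reading at this position shows amino and methoxy side by side. Among the amino compounds, propyl in place of hydrogen on a saturated chain carbon gives a 1.2-fold higher number from compound 2 to compound 4 (0.06 log units; within the scatter), so the drop in the number seen from compound 1 to compound 2 does not carry on past compound 2. Pentyl in place of hydrogen on a saturated chain carbon gives an at least 3.7-fold lower number from compound 1 to compound 4 (0.57 log units; beyond the scatter), and the size of this step is only a bound set by compound 1, whose value is a limit and not a number: the limit of > 50000 nM in this assay, at which 1 of the 4 values shown sits.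

Open, from the compounds shown here alone, is whether a chlorine or a methylamino group on this aromatic carbon would read differently from amino and methoxy, and whether methoxy would match amino on a shorter chain as it does on the chain of compound 3. Also open, going by these compounds, is whether a longer chain, or a carboxylic acid in place of the terminal hydroxyl, would move the number beyond the scatter.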